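Cytotoxicity Limits and a Hydroxylamine Analogue

The source may report more compounds than this note shows. Statements on the series, on what has been measured and on what is new or still open speak of the compounds shown alone.

Measured compounds:
- compound 1 `OCC(CO)OCn1cc(I)c2c(NO)ncnc21`: > 100000 nM
- compound 2 `OCC(CO)OCn1ccc2c(NO)ncnc21`: > 100000 nM
- compound 3 `CCNc1ncnc2c1c(Cl)cn2COC(CO)CO`: > 100000 nM

In an ADME assay on HFF cells (Homo sapiens) for cytotoxicity (on this read-out higher numbers stand for weaker inhibition and lower numbers for stronger inhibition), compound 1 gives > 100000 nM, which is a limit of the assay rather than a number. Compound 2 likewise gives > 100000 nM, again a limit. Compound 3 stands at > 100000 nM, also a limit. Within the data shown here, the one step among measured compounds, a step that the two limits leave unreadable from compound 1 to compound 2, cannot be sized, since both of its ends are limits; all three values sit at the same point, as the limit of > 100000 nM in this assay, at which 3 of the 3 values shown sit, records.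

Compound 4 `OCC(CO)OCn1cc(Cl)c2c(NO)ncnc21` differs from compound 3 by hydroxy in place of ethyl on a nitrogen on an aromatic ring. Among the measured compounds shown here, no measured step bears on this change in this assay, and the only step available is unreadable. With every measured value at the limit, the expectation for compound 4 is that it too shows no cytotoxicity within the tested range, an expected step of a number no higher from compound 3 to compound 4 (the limit leaves the size open) and an estimated value of 100000 nM, in an expected range from 50000 nM to 300000 nM.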

Compound 4, half-maximal inhibitory concentration: > 100000 nM
Compound 4 was reported as a limit (the forecaster's own chance of this, stated with the estimate: 85%); the middle value sits exactly at the limit.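

In this assay compound 4 gives > 100000 nM, which is a limit of the assay. Its steps from compound 1, compound 2 and compound 3 cannot be read, and all four compounds share one point: the limit of > 100000 nM in this assay, at which 4 of the 4 values shown sit. The compounds shown leave open whether any of these changes alters cytotoxicity at all.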